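A few compounds are considered here, and "the series" means these few. Any claim that something is new, unique, unknown or untested is made for them only; others in the source may bear on it.

Compound 1 `Cc1cn([C@@H]2O[C@H](CO[Si](C)(C)C(C)(C)C)[C@@]3(OS(=O)(=O)C=C3NCC(N)=O)[C@H]2O[Si](C)(C)C(C)(C)C)c(=O)n(C)c1=O`: 13500 nM
Compound 2 `Cc1cn([C@@H]2O[C@H](CO[Si](C)(C)C(C)(C)C)[C@@]3(OS(=O)(=O)C=C3NCCC(=O)OCc3ccccc3)[C@H]2O[Si](C)(C)C(C)(C)C)c(=O)n(C)c1=O`: 200000 nM

Among the measured compounds shown here, in a functional assay on HEL cells (Homo sapiens) (a lower number here means that less compound is tolerated, a higher number that more compound is tolerated), compound 2 gives 200000 nM, the higher of the two numbers so far. Compound 3 `Cc1cn([C@@H]2O[C@H](CO[Si](C)(C)C(C)(C)C)[C@@]3(OS(=O)(=O)C=C3NCCC(N)=O)[C@H]2O[Si](C)(C)C(C)(C)C)c(=O)n(C)c1=O` alters the end of its side chain: amino in place of benzyloxy on a carbonyl carbon. Compound 3 therefore ends in the carbamoyl group that compound 1 also carries, while keeping the chain of compound 2.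

For the measured compounds named here, only one measured step bears on this: a 15-fold higher number from compound 1 to compound 2 (1.17 log units; beyond the scatter). This large rise came with (benzyloxycarbonyl)methyl in place of carbamoyl. The new change runs broadly the opposite way, so a large fall is expected, although the match with compound 1 is only partial.

The expected step is a 9.1-fold lower number from compound 2 to compound 3 (0.96 log units; beyond the scatter). The estimated value for compound 3 is 22000 nM, with an expected range of 7000 nM to 70000 nM.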

Compound 3, half-maximal cytotoxic concentration: 14800 nM
Beside the measured number, compound 3's estimate is 1.5-fold (0.17 log units) above it; low and high end bracket the measured number.
By their numbers in this assay, from the lowest: compounds 1 and 3 (each within the scatter of the next); then compound 2.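

With the chain held the same, the end group alone makes a large difference in this assay: amino in place of benzyloxy on a carbonyl carbon gives a 14-fold lower number from compound 2 to compound 3 (1.13 log units; beyond the scatter). Carbamoylmethyl in place of carbamoyl, by contrast, gives a 1.1-fold higher number from compound 1 to compound 3 (0.04 log units; within the scatter), which lies within the usual scatter, so among these three compounds the high number of compound 2 goes with the benzyloxy end and not with the chain. No evidence is available on the reason for this difference.

From the compounds shown here alone, it remains open whether the benzyl part or the ester as a whole carries the effect; a methyl ester or a carboxylic acid at the chain end would help separate the two. Going by these compounds, how a longer chain ending in carbamoyl would behave also remains open.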